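This account rests on a few compounds, and the source may have more. Where it says the series, first, only, none or still open, it means among the compounds named here.

Measured compounds:
- compound 1 `O=C(/C=C/c1ccccc1)OCC1COCCOCCOCCOCCOCCO1`: 48000 nM in a functional assay on SW1573 cells (Homo sapiens) for inhibition, read by sulforhodamine B assay, with a stated time of 48 h; a higher number here means a weaker inhibitor of growth, a lower number a stronger inhibitor of growth
- compound 2 `O=C(CCCCC1CCCCC1)OCC1COCCOCCOCCOCCOCCO1`: 51000 nM in this assay
- compound 3 `O=C(OCC1COCCOCCOCCOCCOCCO1)c1cccnc1`: > 100000 nM in this assay (a limit of the assay, not a number)

All three share one core and differ only in the group on the carbonyl carbon. For compound 3 the value in this assay is a limit, not a measured number (the limit of > 100000 nM in this assay, at which 1 of the 3 values shown sits). The change from compound 1 gives an at least 2.0-fold higher number from compound 1 to compound 3 (0.31 log units; beyond the scatter), and the change from compound 2 gives an at least 1.9-fold higher number from compound 2 to compound 3 (0.29 log units; that floor lies within the scatter), so compound 3 stands at the weak end of what has been seen. Compound 4 `CC(=O)OCC1COCCOCCOCCOCCOCCO1` carries methyl in place of pyridin-3-yl on a carbonyl carbon. Among the measured compounds shown here, no measured step swaps in a group this small, so the two steps that lead to compound 3 are the only guide, and both point to weak growth inhibition once the carbonyl group is no longer bulky and hydrophobic. Compound 4 is therefore expected to sit at or beyond the limit, so that a step that the limit leaves unreadable from compound 3 to compound 4 is anticipated. The estimate for compound 4 in this assay is 150000 nM, with a range from 50000 nM to 500000 nM.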

Compound 4, concentration for 50% growth inhibition: > 100000 nM
Compound 4: a limit, no number (the forecaster's own chance of this, stated with the estimate: 70%); the middle value lies beyond the limit too.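

In this assay compound 4 gives > 100000 nM, which is a limit of the assay and not a number. Replacing the larger groups with methyl, a single carbon and no ring, gives an at least 2.0-fold higher number from compound 1 to compound 4 (0.31 log units; beyond the scatter), and it gives an at least 1.9-fold higher number from compound 2 to compound 4 (0.29 log units; that floor lies within the scatter), so only the first of these steps is sure to exceed the usual scatter. Pyridin-3-yl and methyl cannot be told apart at this carbonyl carbon, and the step between compound 3 and compound 4 cannot be read, because both compounds sit at the same limit: the limit of > 100000 nM in this assay, at which 2 of the 4 values shown sit.

As far as these compounds go, how far compound 3 and compound 4 lie beyond that limit remains open. Also open, from the compounds shown here alone, is whether a plain phenyl ring or a straight octyl chain on the same carbonyl carbon would bring growth inhibition back within measurable range.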